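A few compounds are considered here, and "the series" means these few. Any claim that something is new, unique, unknown or untested is made for them only; others in the source may bear on it.

Two glycoside esters bearing a butenolide side chain have been measured in a functional assay on BV-2 cells (Mus musculus) for inhibition, read by Griess assay, with a stated time of 24 h; a lower number here means a stronger inhibitor, a higher number a weaker inhibitor. Compound 1, `C[C@]12CCC[C@](C)(C(=O)O[C@@H]3O[C@H](CO)[C@@H](O)[C@H](O)[C@H]3O)[C@@H]1CC=C(CO)[C@@H]2CCC1=CCOC1=O`, gives 93200 nM in compound 1's run. Compound 2, `C=C1CC[C@@H]2[C@](C)(CC[C@H](O)[C@]2(C)C(=O)O[C@@H]2O[C@H](CO)[C@@H](O)[C@H](O)[C@H]2O)[C@H]1CCC1=CCOC1=O`, gives 68800 nM. Compound 2 therefore holds the lower of the two numbers, but its nearest neighbour, compound 1, sits within the usual scatter of this assay, so the two cannot be ranked against each other on these data alone; both are weak inhibitors in this assay.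

Compound 3, `C=C1CC[C@@H]2[C@](C)(CC[C@@H](O)[C@]2(C)C(=O)O[C@@H]2O[C@H](CO)[C@@H](O)[C@H](O)[C@H]2O)[C@H]1CCC1=CCOC1=O`, is the next member to be tested in this assay. Relative to compound 2, (the two compounds have the same atoms and bonds and differ only in configuration as drawn: 1 of 10 stereo elements differ; a stereocentre at a saturated ring carbon is drawn S in compound 2 and R in compound 3). Among the compounds with values here, no step between two measured compounds in this set isolates a change of this kind, so there is no measured precedent to lean on. Within the data shown here, with the same atoms and bonds retained and only a single ring stereocentre redrawn, the working expectation is a step from compound 2 to compound 3 of a 1.0-fold higher number from compound 2 to compound 3 (0.01 log units; within the scatter), that is, no shift beyond the scatter in either direction. Compound 3 is accordingly estimated at 70000 nM in this assay, with a plausible range from 30000 nM to 160000 nM.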

Compound 3, half-maximal inhibitory concentration: 24100 nM
For compound 3 the middle estimate is 2.9-fold (0.46 log units) above the measured one; the whole stated range lies above it.
By their numbers in this assay, from the lowest: compound 3; then compounds 2 and 1 (each within the scatter of the next).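

Redrawing the saturated ring stereocentre from S to R gives a 2.9-fold lower number from compound 2 to compound 3 (0.46 log units; beyond the scatter) in this assay, the only step so far that isolates a single change in this series and the first sign that the configuration at this position registers in the read-out. The step is modest, and compound 3, at 24100 nM, remains a weak inhibitor, so the R configuration improves the number here without changing the overall standing of this pair in this assay. The shift can be assigned to this one stereocentre alone because no other structural change accompanies it: the fact that compounds 2 and 3 differ only in the configuration as drawn

Why the R configuration gives the lower number remains open, as does whether the same preference would hold with the butenolide side chain or the glycoside ester replaced. Also open, on these data alone, is how this position responds to a change of group rather than of configuration, such as an amine or a ketone at the same saturated ring carbon.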